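Removing a Methoxy Group From a Cytotoxic Core

A few compounds are considered here, and "the series" means these few. Any claim that something is new, unique, unknown or untested is made for them only; others in the source may bear on it.

Of the compounds shown here, three built on one shared core have been tested in a functional assay on PC-3 cells (Homo sapiens) for cytotoxicity, read by MTT assay, with a stated time of 72 h; on this read-out higher numbers stand for weaker inhibition and lower numbers for stronger inhibition. Compound 1 `CCCOCNc1n[n+]([O-])c2cc(OC)ccc2[n+]1[O-]` gives 6570 nM. Compound 2 `COCNc1n[n+]([O-])c2ccccc2[n+]1[O-]` gives 7510 nM. Compound 3 `COc1ccc2c(c1)[n+]([O-])nc(NCOCc1ccccc1)[n+]2[O-]` gives 8580 nM, the highest of the three numbers, yet its gaps to compound 2 and to compound 1 both fall within the scatter, so the three cannot be told apart. Going by the values given here, the only single-site step among them, a 1.3-fold higher number from compound 1 to compound 3 (0.12 log units; within the scatter), likewise changes nothing beyond the scatter.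

Compound 4 `[O-][n+]1nc(NCOCc2ccccc2)[n+]([O-])c2ccccc21` has not yet been measured. It differs from compound 3 by hydrogen in place of methoxy on an aromatic carbon. Among the compounds with values here, no measured pair differs in that place alone, so there is no direct step to lean on. The closest hint comes from compound 2, which lacks the methoxy group and gives 7510 nM, set against compound 1, which carries it and gives 6570 nM; those two also differ in the chain on the nitrogen, and their values sit within the scatter of each other. On that basis the expected step of a 1.1-fold lower number from compound 3 to compound 4 (0.03 log units; within the scatter) is small, with no clear direction. Compound 4 is therefore estimated at 8000 nM, expected to fall between 4000 nM and 16000 nM.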

Compound 4, half-maximal inhibitory concentration: 13400 nM
Compound 4: middle estimate off by 1.7-fold (0.22 log units), on the low side, and the stated range covers the measured number.
By their numbers in this assay, from the lowest: compounds 1, 2, 3 and 4 (each within the scatter of the next, the first and the last beyond it).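

Going by these compounds alone, compounds 3 and 4 form the first pair that isolates the methoxy position, with the chain on the nitrogen unchanged. In this assay, hydrogen in place of methoxy on this aromatic carbon gives a 1.6-fold higher number from compound 3 to compound 4 (0.19 log units; within the scatter), so this pair shows no effect of the group that can be told apart from ordinary variation between repeated measurements, and the methoxy group is not required for a measurable number in this assay. With no methoxy group on the core, the phenyl change on the chain gives a 1.8-fold higher number from compound 2 to compound 4 (0.25 log units; within the scatter), so that change also stays inside the scatter, now on the core without methoxy; nothing available explains either step.

These two steps cover only methoxy and hydrogen at the aromatic position, so a chlorine atom or an amine on that carbon might still move the number beyond the scatter. On the chain the compounds shown cover only the ends already tested, which leaves open whether a carboxylic acid or a much longer carbon chain would give a clearly different result.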